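A few compounds are considered here, and "the series" means these few. Any claim that something is new, unique, unknown or untested is made for them only; others in the source may bear on it.

Measured compounds:
compound 1 `COc1cccc(C(F)(F)F)c1C(=O)NC1(c2ccccc2)CCCN(C)C1`: 1500 nM
compound 2 `COc1cc(C(F)(F)F)cc(SC)c1C(=O)NC1(c2cccc(Cl)c2)CCCN(C)C1`: 25 nM

In an assay on cells for inhibition of sodium- and chloride-dependent glycine transporter 1 (Homo sapiens) (on this read-out lower numbers stand for an effect already at smaller amounts and higher numbers for an effect only at larger amounts of compound), compound 2 gives 25 nM, the lower of the two numbers, while compound 1 gives 1500 nM, a gap beyond the scatter. Compound 3 `COc1cc(C(F)(F)F)cc(SC)c1C(=O)NC1(c2ccncn2)CCCN(C)C1` has not been measured; its difference from compound 2 is pyrimidin-4-yl in place of 3-chlorophenyl on a saturated ring carbon. Nothing measured shows what this change does here, so the expectation rests only on compound 2. The step of a 4.0-fold higher number from compound 2 to compound 3 (0.60 log units; beyond the scatter) is expected to be a moderate loss, beyond the scatter, but not large. Compound 3 is estimated at 100 nM, within 30 nM to 400 nM.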

Compound 3, half-maximal effective concentration: 1700 nM
The estimate for compound 3 lay 17-fold (1.23 log units) below the measured number, outside the stated range (above it).
By their numbers in this assay, from the lowest: compound 2; then compounds 1 and 3 (each within the scatter of the next).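

In this assay the saturated ring carbon proves sensitive to the group it carries: with pyrimidin-4-yl in place of 3-chlorophenyl, the change is a 68-fold higher number from compound 2 to compound 3 (1.83 log units; beyond the scatter) and counts as large. Among the compounds shown here, this is the only single-place comparison among the compounds, so it gives the first direct reading of this position. Nothing available accounts for the size of this loss.

The compounds shown do not separate the departure of the chlorine from the arrival of the two ring nitrogens. A phenyl bearing a 3-fluoro group, or a pyridin-3-yl group, on this carbon would bear on that question.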